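This account rests on a few compounds, and the source may have more. Where it says the series, first, only, none or still open, it means among the compounds named here.

Among the measured compounds shown here, compound 1 `O=C(/C=C/c1ccc(O)c(O)c1)N1CCN(S(=O)(=O)c2cccc3cnccc23)CC1` is one of three compounds measured in an assay on isolated protein for inhibition of Rho-associated protein kinase 2 (Homo sapiens), read by 33P incorporation, with a stated time of 30 min, in the presence of a further agent that is not named here (a lower number here means a stronger inhibitor, a higher number a weaker inhibitor), where compound 1 gives 790 nM. Compound 2 `O=C(/C=C/c1ccc(O)c(O)c1)N1CCCN(S(=O)(=O)c2cccc3cnccc23)CC1` gives 2130 nM in this assay, a higher number than compound 1, while compound 3 `O=C(CCc1ccc(O)c(O)c1)N1CCN(S(=O)(=O)c2cccc3cnccc23)CC1` gives 320 nM, a lower one; compound 1 therefore stands second highest of the three, with compound 3 nearest and compound 2 furthest from it.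

Compound 4 `COc1cc(/C=C/C(=O)N2CCN(S(=O)(=O)c3cccc4cnccc34)CC2)ccc1O` differs from compound 1 by methyl in place of hydrogen on an oxygen on an aromatic ring. For the measured compounds named here, the only step told in this set, a 2.5-fold lower number from compound 1 to compound 3 (0.39 log units; beyond the scatter), alters the chain on the carbonyl carbon and leaves both ring oxygens untouched, and the gap between compound 1 and compound 2 concerns the ring that carries the sulfonyl group. Going by the values given here, no measured step bears on a methyl on an aromatic oxygen, so the direction of the step cannot be read from these compounds. Compound 4 is expected to sit close to compound 1, with an estimated step of a 1.5-fold higher number from compound 1 to compound 4 (0.18 log units; within the scatter), most likely not beyond the scatter. The value of compound 4 in this assay is estimated at 1200 nM, within a range from 400 nM to 4000 nM.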

Compound 4, half-maximal inhibitory concentration: 2330 nM
The estimate for compound 4 lay 1.9-fold (0.29 log units) below the measured number, and the stated range covers the measured number.
By their numbers in this assay, from the lowest: compound 3; then compound 1; then compounds 2 and 4 (each within the scatter of the next).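

In this assay, the change from 3,4-dihydroxyphenyl to 4-hydroxy-3-methoxyphenyl gives a 2.9-fold higher number from compound 1 to compound 4 (0.47 log units; beyond the scatter), so placing a methyl on this aromatic oxygen makes the inhibitor weaker rather than leaving it unchanged. The earlier compounds shown here varied only the chain on the carbonyl carbon and the ring carrying the sulfonyl group, and this change runs in the opposite direction to a 2.5-fold lower number from compound 1 to compound 3 (0.39 log units; beyond the scatter). Nothing available explains this loss.

The compounds shown leave open whether the other hydroxy on the aromatic ring would respond to a methyl in the same way. They also do not tell how an ethyl on this oxygen, or an amine in place of the hydroxy, would read in this assay.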